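A few compounds are considered here, and "the series" means these few. Any claim that something is new, unique, unknown or untested is made for them only; others in the source may bear on it.

Measured in an ADME assay on A549 cells (Homo sapiens) for cytotoxicity, read by resazurin assay, with a stated time of 48 h; on this read-out higher numbers stand for lower toxicity in this test and lower numbers for higher toxicity in this test:
compound 1, `CCCNc1ccc(NC(=O)c2cc(Cl)ccc2O)c(Cl)c1`, gives 22500 nM;
compound 2, `O=C(Nc1ccc(NCC2CCCC2)cc1Cl)c1cc(Cl)ccc1O`, gives 21500 nM;
compound 3, `O=C(Nc1ccc(NCc2cc(Cl)cc(Cl)c2)cc1Cl)c1cc(Cl)ccc1O`, gives 13300 nM.

Compound 2 holds the second highest of these three numbers, nearest to compound 1 and furthest from compound 3, and all three lie within the scatter of one another. Compound 4, `O=C(Nc1ccc(NCc2cccc(Br)n2)cc1Cl)c1cc(Cl)ccc1O`, differs from compound 2 by 6-bromopyridin-2-yl in place of cyclopentyl on a saturated chain carbon bound to a nitrogen on an aromatic ring. The step bearing most on this is a 1.6-fold lower number from compound 2 to compound 3 (0.21 log units; within the scatter), in which 3,5-dichlorophenyl took the place of cyclopentyl on a saturated chain carbon bound to a nitrogen on an aromatic ring; a 1.0-fold lower number from compound 1 to compound 2 (0.02 log units; within the scatter) and a 1.7-fold lower number from compound 1 to compound 3 (0.23 log units; within the scatter) were likewise within the scatter. For compound 4 no step beyond the scatter is therefore expected in this assay, at most a small drift to a lower number, estimated as a 1.4-fold lower number from compound 2 to compound 4 (0.16 log units; within the scatter). Compound 4 is expected to give 15000 nM, in the range 7000 nM to 30000 nM.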

Compound 4, half-maximal cytotoxic concentration: 92300 nM
Compound 4: middle estimate off by 6.2-fold (0.79 log units), on the low side, and the stated range ends below it.
By their numbers in this assay, from the lowest: compounds 3, 2 and 1 (each within the scatter of the next); then compound 4.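

In this assay, a change on the saturated chain carbon bound to a nitrogen on an aromatic ring can reach beyond the scatter: 6-bromopyridin-2-yl brought a 4.3-fold higher number from compound 2 to compound 4 (0.63 log units; beyond the scatter) and a 4.1-fold higher number from compound 1 to compound 4 (0.61 log units; beyond the scatter) as well as a 6.9-fold higher number from compound 3 to compound 4 (0.84 log units; beyond the scatter) among these compounds. An aromatic ring alone does not go with this, as the 3,5-dichlorophenyl of compound 3 stayed within the scatter of compound 1 and compound 2. Nothing measured here explains the step.

As far as these compounds go, it remains open whether the step follows the bromine or the ring nitrogen, which a plain pyridin-2-yl or a bromophenyl group would separate.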